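The source may hold more compounds than are shown below. What is called first, only, known or untested is meant among the compounds shown, and "the series" means these compounds.

Compound 2 `CCCC(Oc1ccc(-n2cc(C(=O)N(C)C)cn2)cc1)c1ccc(C(=O)NCCC(=O)O)cc1` carries a dimethylcarbamoyl group on its five-membered aromatic ring. In a functional assay on cells for antagonist activity at Glucagon receptor (Homo sapiens), read by cAMP accumulation, in the presence of a further agent that is not named here (a lower number here means a stronger inhibitor, a higher number a weaker inhibitor), compound 2 gives only a limit of the assay, > 30000 nM, and no number. That is the limit of > 30000 nM in this assay, at which 1 of the 3 values shown sits; compound 2 therefore stands as the weakest of the three measured compounds. Compound 1 `O=C(O)CCNC(=O)c1ccc(C(Oc2ccc(-n3cc(C(F)(F)F)cn3)cc2)C2CCCC2)cc1`, with a trifluoromethyl group in the corresponding place and a cyclopentyl group on the chain carbon, gives 4000 nM in this assay. Compound 3 `CC(C)(C)C(Oc1ccc(-n2cc(C(F)(F)F)cn2)cc1)c1ccc(C(=O)NCCC(=O)O)cc1` gives 4300 nM in this assay, and the step of a 1.1-fold higher number from compound 1 to compound 3 (0.03 log units; within the scatter) lies within the scatter.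

Compound 4 `CCCC(Oc1ccc(-n2cc(OC)cn2)cc1)c1ccc(C(=O)NCCC(=O)O)cc1` has not yet been measured. It differs from compound 2 in one place: methoxy in place of dimethylcarbamoyl on an aromatic carbon. Among the compounds with values here, no measured step follows this change; the single measured step concerns the chain carbon and does not bear on the ring substituent. Within the data shown here, compound 1 and compound 3 differ from compound 2 in more than one place, so their values show only that the two compounds with a trifluoromethyl group on that ring give measured numbers in this assay.

With nothing to anchor the change, compound 4 is expected to fall between those values and the limit of compound 2, estimated at 15000 nM, within 4000 nM to 60000 nM, a step of an at least 2.0-fold lower number from compound 2 to compound 4 (0.30 log units; that floor lies within the scatter) that is expected but uncertain.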

Compound 4, antagonist equilibrium constant: > 23000 nM
Compound 4: only a limit was reported (the forecaster's own chance of this, stated with the estimate: 35%); middle value at least 1.5-fold (0.18 log units) from the limit.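

Compound 4 gives only a limit of the assay: the limit of > 23000 nM in this assay, at which 1 of the 4 values shown sits. Compound 2 also gives only a limit: the limit of > 30000 nM in this assay, at which 1 of the 4 values shown sits. With a limit on each side, the step between compound 2 and compound 4 cannot be read. The compounds shown leave open how strong an inhibitor either one is, and whether methoxy or dimethylcarbamoyl gives the stronger inhibitor.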